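This account rests on a few compounds, and the source may have more. Where it says the series, first, only, none or still open, it means among the compounds named here.

The measured compounds:

Compound 1, `Oc1ccc(-c2cc(-c3ccsc3)cc(-c3ccccc3O)n2)cc1`, gives > 50000 nM in a functional assay on HCT-15 cells (Homo sapiens) for cytotoxicity, read by CCK-8 assay (on this read-out lower numbers stand for stronger inhibition and higher numbers for weaker inhibition), a limit of the assay.
Compound 2, `Oc1ccc(-c2cc(-c3ccsc3)cc(-c3cccc(O)c3)n2)cc1`, gives 1180 nM in this assay.
Compound 3, `Oc1cccc(-c2cc(-c3ccoc3)cc(-c3ccccc3O)n2)c1`, gives > 50000 nM in this assay, again a limit.

Two of the three values sit at the limit of > 50000 nM in this assay, at which 2 of the 3 values shown sit, so only compound 2 has a number. For the measured compounds named here, the one step that can be counted, an at least 42-fold lower number from compound 1 to compound 2 (1.62 log units; beyond the scatter), goes with 3-hydroxyphenyl in place of 2-hydroxyphenyl on an aromatic carbon. How the core of compound 3 differs from the core of compound 1 is not broken down here.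

Compound 4, `Oc1cccc(-c2cc(-c3ccoc3)cc(-c3cccc(O)c3)n2)c1`, is not yet measured in this assay. It stands to compound 3 as compound 2 stands to compound 1: 3-hydroxyphenyl in place of 2-hydroxyphenyl on an aromatic carbon. The two places are not the same word for word, one being meta to a 4-hydroxyphenyl group and a thiophen-3-yl group, the other meta to a 3-hydroxyphenyl group and a furan-3-yl group, so this is the same kind of change, not the same change.

Resting on compound 1 and compound 2 and the step of an at least 42-fold lower number from compound 1 to compound 2 (1.62 log units; beyond the scatter), compound 4 is expected to move by about an at least 16-fold lower number from compound 3 to compound 4 (1.22 log units; beyond the scatter) from compound 3, though compound 3 only shows a limit. Compound 4 is estimated at 3000 nM, between 700 nM and 20000 nM.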

Compound 4, half-maximal inhibitory concentration: 1020 nM
Estimate against measurement, compound 4: 2.9-fold (0.47 log units) above, and the stated range covers the measured number.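

In this assay, putting 3-hydroxyphenyl in place of 2-hydroxyphenyl on the second core gives an at least 49-fold lower number from compound 3 to compound 4 (1.69 log units; beyond the scatter), so the change goes the same way and is large on both cores shown. Set side by side, the two steps compare as follows: the same change on two cores in this assay, an at least 42-fold lower number (1.62 log units; beyond the scatter) from compound 1 to compound 2 and an at least 49-fold lower number (1.69 log units; beyond the scatter) from compound 3 to compound 4; the limit leaves it open whether they differ. This supports carrying the change between these two cores, but it does not give the true size of either step or show that the change would carry to any other core, and the starting point of each step is only a limit: the limit of > 50000 nM in this assay, at which 2 of the 4 values shown sit.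

The compounds shown leave open what thiophen-3-yl and furan-3-yl do on their own, since no pair here differs in that place alone. They also leave open whether the step would survive if the hydroxyl on the moved ring gave way to an amine or a carboxylic acid.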